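Ester series on the shared core: chloro to methyl

A few compounds are considered here, and "the series" means these few. Any claim that something is new, unique, unknown or untested is made for them only; others in the source may bear on it.

Among the compounds with values here, two esters of the shared core have numbers so far. Compound 1 `Cc1cc2c(C(C)C)ccc(C)c2cc1OC(=O)c1cccc(C(F)(F)F)c1` carries a trifluoromethyl on the ester side; in a functional assay on MCF7 cells (Homo sapiens) for antiproliferative activity, read by sulforhodamine B assay, with a stated time of 48 h, tested at 50 uM (a lower number here means less inhibition, a higher number more inhibition at the concentration tested (going by the name of the read-out)), compound 1 gives 41.5%. Compound 2 `CC1=CC[C@H](C(C)C)c2cc(C)c(OC(=O)c3ccc(Cl)cc3)cc21` carries a chloro on the ester side; in this assay compound 2 gives 79.7%. Compound 2 thus stands highest of the two numbers, and its gap to compound 1 lies beyond the scatter. Within the data shown here, no two measured compounds differ in one place only, so no single step has yet been measured.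

Compound 3 `CC1=CC[C@H](C(C)C)c2cc(C)c(OC(=O)c3ccc(C)cc3)cc21` is not yet measured. It differs from compound 2 in one place: methyl in place of chloro on an aromatic carbon The chloro leaves and a methyl enters on the same aromatic carbon, para to a large group, with the ester and the rest of the core unchanged.

Among the measured compounds shown here, with no measured step of this kind to lean on, the size of the step is open. The expectation is a modest fall, or none beyond the scatter. The estimated step is a number 9.7 percentage points lower from compound 2 to compound 3 (within the scatter). Compound 3 is expected to give 70% in this assay, with a range from 50% to 88%.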

Compound 3, a percentage reported as inhibition, at one concentration (the size of the read-out at that concentration, not a potency): 65%
Estimate against measurement, compound 3: 5 percentage points above; measured number inside the range.
By their numbers in this assay, from the lowest: compound 1; then compound 3; then compound 2.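

In this assay, within the data shown here, the change from 4-chlorophenyl to 4-methylphenyl gives the first step measured in one place alone: a number 14.7 percentage points lower from compound 2 to compound 3 (beyond the scatter). The position therefore registers an exchange of one heavy atom for one heavy atom, even though neither chloro nor methyl adds a ring, a hydrogen-bond donor, a hydrogen-bond acceptor or a net charge, and with compound 3 at 65% the chloro is not required for a substantial read-out at the concentration tested. The data on hand offer no measured basis for explaining this step, which stands here as an observation only.

A single pair cannot show whether the outcome follows some wider trend at this aromatic carbon, and an amine, a methoxy group, a fluoro group or a longer chain such as propyl in the same place would be needed to define how far the read-out moves there. On these data alone, whether the step keeps its size when the ester link is replaced by an amide also remains open, as does how the read-out at one concentration relates to potency.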